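Swapping the Dimethylpiperidine for a Methylpiperazine

The source may hold more compounds than are shown below. What is called first, only, known or untested is meant among the compounds shown, and "the series" means these compounds.

Three measured analogues share one core. In a functional assay on DU-145 cells (Homo sapiens) for cytotoxicity, read by sulforhodamine B assay, with a stated time of 48 h (on this read-out higher numbers stand for weaker inhibition of growth and lower numbers for stronger inhibition of growth), compound 1 `N#Cc1ccc(Nc2nc(Oc3ccnc4ccccc34)nc(N3CCN(c4ccc(F)cc4)CC3)n2)cc1C(F)(F)F` reaches only a limit, > 100000 nM. Compound 2 `CC(=O)N1CCN(c2nc(Nc3ccc(C#N)c(C(F)(F)F)c3)nc(Oc3ccnc4ccccc34)n2)CC1` gives 75100 nM in this assay. Compound 3 `CC1CC(C)CN(c2nc(Nc3ccc(C#N)c(C(F)(F)F)c3)nc(Oc3ccnc4ccccc34)n2)C1` gives 27200 nM, the lowest of the two real numbers shown. The measured changes are an at least 1.3-fold lower number from compound 1 to compound 2 (0.12 log units; that floor lies within the scatter) and a 2.8-fold lower number from compound 2 to compound 3 (0.44 log units; beyond the scatter). Compound 4 `CN1CCN(c2nc(Nc3ccc(C#N)c(C(F)(F)F)c3)nc(Oc3ccnc4ccccc34)n2)CC1` differs from compound 3 by 4-methylpiperazin-1-yl in place of 3,5-dimethylpiperidin-1-yl on an aromatic carbon. Neither step copies this exchange, yet a return toward a piperazine ring is expected to push the number back up, because a 2.8-fold lower number from compound 2 to compound 3 (0.44 log units; beyond the scatter) ran the other way when the piperazine ring gave way to the piperidine ring. Compound 4 is therefore expected to give 55000 nM, in a range of 20000 nM to 150000 nM. For compound 4 this would mean an expected step of a 2.0-fold higher number from compound 3 to compound 4 (0.31 log units; beyond the scatter).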

Compound 4, concentration for 50% growth inhibition: 51200 nM
Beside the measured number, compound 4's estimate is 1.1-fold (0.03 log units) above it; low and high end bracket the measured number.
By their numbers in this assay, from the lowest: compounds 3, 4 and 2 (each within the scatter of the next, the first and the last beyond it). At a limit, above all of these: compound 1.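

At this place, opposite the ring nitrogen, 4-methylpiperazin-1-yl in place of 3,5-dimethylpiperidin-1-yl gives a 1.9-fold higher number from compound 3 to compound 4 (0.27 log units; within the scatter) in this assay, so this exchange, unlike the earlier one at the same place, does not leave the scatter. Methyl in place of acetyl on the ring amine nitrogen gives a 1.5-fold lower number from compound 2 to compound 4 (0.17 log units; within the scatter), which does not separate the two groups. Compound 1 stands at a limit, so an at least 1.9-fold lower number from compound 1 to compound 4 (0.29 log units; that floor lies within the scatter) is only a floor: the limit of > 100000 nM in this assay, at which 1 of the 4 values shown sits.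

As far as these compounds go, what a morpholine ring or an unsubstituted piperazine would give at this place stays open.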